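Working notes: ethoxy in place of amino

A few compounds are considered here, and "the series" means these few. Any claim that something is new, unique, unknown or untested is made for them only; others in the source may bear on it.

Measured so far in a physicochemical assay for lipophilicity; a higher number here means a more lipophilic compound, a lower number a more polar compound:
- compound 1 `C/C=C/C=C/C(=O)Nc1cccc([N+](=O)[O-])c1` gives 2.49
- compound 2 `C/C=C/C=C/C(N)=O` gives 0.6
- compound 3 `C/C=C/C=C/C(=O)NCCC` gives 1.66

Compound 2, at 0.6, holds the lowest of the three numbers in this assay, with compound 3 nearest and compound 1 furthest.

The next structure is compound 4 `C/C=C/C=C/C(=O)OCC`, still unmeasured. Its difference from compound 2 is ethoxy in place of amino on a carbonyl carbon, in words ethoxy in place of amino on a carbonyl carbon.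

Within the data shown here, one measured step bears on this change: a number 1.06 log units higher from compound 2 to compound 3 (beyond the scatter), which places propyl in place of hydrogen on an amide-type nitrogen. It is only a partial guide. The nitrogen stays in that step, whereas here the whole amino group leaves. Among the measured compounds shown here, no measured step shows such an exchange. Compound 1, at 2.49, differs from compound 2 in a larger group, and its value shows only how high the numbers reach so far.

On the evidence of compound 3 at 1.66, a large rise beyond the scatter is expected, somewhat greater than that measured step. The expected change is a number 1.70 log units higher from compound 2 to compound 4 (beyond the scatter). For compound 4 the estimate is 2.3, with an expected range from 1.8 to 2.8.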

Compound 4, partition coefficient: 1.84
Estimate against measurement, compound 4: 0.46 log units above, and the stated range covers the measured number.
By their numbers in this assay, from the lowest: compound 2; then compounds 3 and 4 (each within the scatter of the next); then compound 1.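

In this assay the exchange of amino for ethoxy on a carbonyl carbon gives a number 1.24 log units higher from compound 2 to compound 4 (beyond the scatter) and so shows that the number also moves when the amino group leaves altogether, with its nitrogen and its hydrogen-bond donor, a case that a number 1.06 log units higher from compound 2 to compound 3 (beyond the scatter) could not show with the nitrogen kept. Two different changes at the same end of compound 2 now arrive at numbers within the scatter of each other, compound 3 at 1.66 and compound 4 at 1.84, so this assay does not tell these two end groups apart. Nothing at hand accounts for the size of the new step.

The compounds shown leave open how much of that step goes with the loss of the amino group and how much with the carbons that ethoxy brings in. A methoxy or butoxy group on the same carbonyl carbon, or the carboxylic acid formed with a hydroxyl group there, would help to separate these two parts.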